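Hydroxyphenyl series: metabolic stability notes, methyl addition

This account rests on a few compounds, and the source may have more. Where it says the series, first, only, none or still open, it means among the compounds named here.

Measured so far in an ADME assay on microsomes from liver (Mus musculus) for metabolic stability, read by LC-MS, using NADPH, with a stated time of 60 min, tested at 1 uM; on this read-out lower numbers stand for slow clearance and higher numbers for fast clearance:
compound 1 `COc1ccc(-n2c(N)nc3ccccc32)c(O)c1`: compound 1 gives 271 uL/min
compound 2 `Cc1ccc(-n2c(N)nc3ccccc32)c(O)c1`: compound 2 gives 97 uL/min
compound 3 `Nc1nc2ccccc2n1-c1ccccc1O`: compound 3 gives 22 uL/min

Compound 2 stands second highest of the three numbers in this assay. Its nearest neighbour is compound 1, where the step is a 2.8-fold lower number from compound 1 to compound 2 (0.45 log units; beyond the scatter) (methyl in place of methoxy on an aromatic carbon); its furthest is compound 3, where the step is a 4.4-fold lower number from compound 2 to compound 3 (0.64 log units; beyond the scatter) (hydrogen in place of methyl on an aromatic carbon).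

Compound 4 `Cc1cc(O)c(-n2c(N)nc3ccccc32)cc1C` has not yet been measured. It differs from compound 2 by methyl in place of hydrogen on an aromatic carbon.

Going by the values given here, the steps that bear on this change are a 4.4-fold lower number from compound 2 to compound 3 (0.64 log units; beyond the scatter) and a 12-fold lower number from compound 1 to compound 3 (1.09 log units; beyond the scatter): in both, removing a group from the same ring leaves a lower number, so going the other way and adding a methyl should move the number upward beyond the scatter in this assay, probably by a modest step, though only a single methyl addition is on record. Compound 4 is therefore expected to give 220 uL/min, with a range from 110 uL/min to 450 uL/min. That estimate corresponds to an expected step of a 2.3-fold higher number from compound 2 to compound 4 (0.36 log units; beyond the scatter).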

Compound 4, intrinsic clearance in a liver preparation (reported as CLH), per the amount of preparation that the assay uses: 76 uL/min
Beside the measured number, compound 4's estimate is 2.9-fold (0.46 log units) above it, outside the stated range (below it).
By their numbers in this assay, from the lowest: compound 3; then compounds 4 and 2 (each within the scatter of the next); then compound 1.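

In this assay, methyl in place of hydrogen at this carbon, ortho to a methyl group and para to a hydroxy group, gives a 1.3-fold lower number from compound 2 to compound 4 (0.11 log units; within the scatter). This position therefore differs from the ring carbon that carries the methyl of compound 2, where the change gives a 4.4-fold lower number from compound 2 to compound 3 (0.64 log units; beyond the scatter), so the sensitivity seen at that carbon does not extend to every carbon of this ring. No measurement at hand accounts for the difference between the two positions.

The compounds shown leave open whether this carbon would tolerate a larger or different group, such as an ethyl chain, an amine or a carboxylic acid, as it tolerates methyl. They also leave open whether methyl here would read the same without the neighbouring methyl, on the core of compound 3.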